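The source may hold more compounds than are shown below. What is called first, only, known or untested is meant among the compounds shown, and "the series" means these compounds.

Compound 1 `CCCCNCCCCOc1c(O)cc(O)c2c(=O)cc(-c3ccccc3)oc12`: "not determined" (no result reported)
Compound 2 `O=c1cc(-c2ccccc2)oc2c(OCCCN3CCCC3)c(O)cc(O)c12`: > 100000 nM

Within the data shown here, only two compounds have been examined so far in a functional assay on A549 cells (Homo sapiens) for cytotoxicity, read by MTT assay, with a stated time of 48 h (on this read-out lower numbers stand for stronger inhibition and higher numbers for weaker inhibition), and neither gives a plain number. For compound 1 the outcome in this assay is recorded as "not determined" (no result reported), with no result reported. For compound 2 the outcome in this assay is > 100000 nM, which is a limit of the assay and not a measured number; this is the limit of > 100000 nM in this assay, at which 1 of the 2 values shown sits. Compound 3 `CN(C)CCCOc1c(O)cc(O)c2c(=O)cc(-c3ccccc3)oc12` has not yet been tested. It differs from compound 2 in one place: dimethylamino in place of pyrrolidin-1-yl on a saturated chain carbon, three bonds along the chain from an oxygen on an aromatic ring. Among the measured compounds shown here, with no measured step to lean on, the expectation is that this change will move the result by no more than the usual scatter, so the step from compound 2 to compound 3 is estimated as a step that the limit leaves unreadable from compound 2 to compound 3. Compound 3 is therefore expected to give about 150000 nM in this assay, in the range from 50000 nM to 500000 nM, most likely again reported only as a limit.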

Compound 3, half-maximal inhibitory concentration: > 100000 nM
Compound 3 ended at the assay's limit; the forecaster's own chance of this, stated with the estimate: 75%; the middle value lies beyond the limit too.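

No new step can be read between compound 2 and compound 3 in this assay, since both sit at the same limit: the limit of > 100000 nM in this assay, at which 2 of the 3 values shown sit.

From the compounds shown here alone, whether exchanging pyrrolidin-1-yl for dimethylamino changes the result at all stays open, as does how either compound would compare with a value inside the measurable range.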